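Swapping the linker on the indole nitrogen

The source may hold more compounds than are shown below. What is called first, only, known or untested is meant among the compounds shown, and "the series" means these compounds.

Of the compounds shown here, three have been measured so far in an assay on isolated protein for binding affinity to Bile acid receptor (Homo sapiens), read by FRET; on this read-out higher numbers stand for an effect only at larger amounts of compound and lower numbers for an effect already at smaller amounts. Compound 1, `CC(C)c1onc(-c2c(Cl)cccc2Cl)c1COc1ccc2sc(-c3ccc(C(=O)O)cc3)cc2c1`, gives 280 nM. Compound 2, `CC(C)c1onc(-c2c(Cl)cccc2Cl)c1COc1ccc2[nH]c(-c3cccc(C(=O)O)c3)cc2c1`, gives 480 nM. Compound 3, `CC(C)c1onc(-c2c(Cl)cccc2Cl)c1COc1ccc2c(ccn2Cc2ccc(C(=O)O)cc2)c1`, gives 160 nM. Among these, compound 3 has the lowest of the three numbers; its gap to compound 1 is within the usual scatter of this assay, so the two cannot be told apart, while its gap to compound 2 is beyond the scatter.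

Compound 4, `CC(C)c1onc(-c2c(Cl)cccc2Cl)c1COc1ccc2c(ccn2C(=O)c2cccc(C(=O)O)c2)c1`, has not yet been measured. It differs from compound 3 in one place: (3-carboxyphenyl)carbonyl in place of 4-carboxybenzyl on an aromatic nitrogen. Going by the values given here, no step between two measured compounds matches this change, so there is no direct precedent for its size. The change replaces a carbon linker by a carbonyl and moves the acid from one position of the phenyl ring to another, and two changes at once leave room for a noticeable shift. The expectation is a step from compound 3 to compound 4 of a 2.8-fold higher number from compound 3 to compound 4 (0.45 log units; beyond the scatter) in this assay, toward a larger number. Compound 4 is therefore estimated at 450 nM, with a range from 150 nM to 1400 nM.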

Compound 4, half-maximal effective concentration: 150 nM
Compound 4: the middle estimate sits 3.0-fold (0.48 log units) above what was measured, within the range that was stated.
By their numbers in this assay, from the lowest: compounds 4, 3, 1 and 2 (each within the scatter of the next, the first and the last beyond it).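

In this assay, putting (3-carboxyphenyl)carbonyl in place of 4-carboxybenzyl on the aromatic nitrogen gives a 1.1-fold lower number from compound 3 to compound 4 (0.03 log units; within the scatter), so compound 3 and compound 4 cannot be told apart. Going by these compounds alone, this is the first sign of how much room this position allows: the link to the phenyl ring and the place of the carboxylic acid on that ring both differ, yet the reading stays within the normal spread of repeat measurements. Nothing available here explains why the number holds.

A single step cannot show whether each of the two differences is without effect on its own or whether they cancel each other, and 3-carboxybenzyl or (4-carboxyphenyl)carbonyl on the same nitrogen would pull them apart. Also open, as far as these compounds go, is how far this tolerance extends, for example to a longer chain in place of the carbonyl, or to an amine in place of the carboxylic acid on the phenyl ring.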